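This account rests on a few compounds, and the source may have more. Where it says the series, first, only, none or still open, it means among the compounds named here.

Measured so far in an ADME assay on HaCaT cells (Homo sapiens) for cytotoxicity, read by MTT assay, with a stated time of 48 h; a lower number here means a stronger inhibitor, a higher number a weaker inhibitor:
- compound 1 `Fc1ccc(-c2nn(-c3ccccc3)cc2-c2nc3cc(Br)ccc3[nH]2)cc1`: 21800 nM
- compound 2 `Clc1ccc(-c2nn(-c3ccccc3)cc2-c2nc3cc(Br)ccc3[nH]2)cc1`: a limit, > 50000 nM
- compound 3 `COc1ccc(-c2nn(-c3ccccc3)cc2-c2nc3cc(F)ccc3[nH]2)cc1`: a limit, > 50000 nM

Compound 2 carries chloro in place of fluoro on an aromatic carbon relative to compound 1, and that change gives an at least 2.2-fold higher number from compound 1 to compound 2 (0.36 log units; beyond the scatter), a step read against (the limit of > 50000 nM in this assay, at which 2 of the 3 values shown sit). Compound 4 `COc1ccc(-c2nn(-c3ccccc3)cc2-c2nc3cc(Cl)ccc3[nH]2)cc1` is unmeasured in this assay; it carries chloro in place of fluoro on an aromatic carbon relative to compound 3, the same kind of change as that from compound 1 to compound 2, though here the place is part of a fused or bridged system of two rings, meta to a fused ring and para to a fused ring, whereas in compound 1 it is para to a large group. The difference between the core of compound 3 and the core of compound 1 is not broken down here. Compound 3 already sits at a limit in this assay, so compound 4 is expected to sit at or beyond that limit, an expected step that the limit leaves unreadable from compound 3 to compound 4, resting on the direction of an at least 2.2-fold higher number from compound 1 to compound 2 (0.36 log units; beyond the scatter). The estimate for compound 4 is 70000 nM, expected between 35000 nM and 200000 nM.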

Compound 4, half-maximal inhibitory concentration: > 50000 nM
Compound 4: no number, only a limit (the forecaster's own chance of this, stated with the estimate: 80%); the middle value does not contradict the limit.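

Compound 3 and compound 4 both sit at a limit in this assay, so no step between them can be read: the limit of > 50000 nM in this assay, at which 3 of the 4 values shown sit.

The compounds shown leave open whether chloro in place of fluoro at this place changes the number at all.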